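Trimming the ester side chain of compound 2

This account rests on a few compounds, and the source may have more. Where it says the series, first, only, none or still open, it means among the compounds named here.

Compound 1 `O=C1C=C[C@@H](OCc2ccccc2)[C@@H]([C@@H](COC(=O)/C=C/c2ccccc2)OCc2ccccc2)O1` and compound 2 `O=C1C=C[C@@H](OCc2ccccc2)[C@@H]([C@@H](COC(=O)/C=C/c2ccc([N+](=O)[O-])cc2)OCc2ccccc2)O1` share one core and differ only by a nitro group. In a functional assay on HL-60 cells (Homo sapiens) for antiproliferative activity, read by MTT assay, with a stated time of 6 days (a lower number here means a stronger inhibitor, a higher number a weaker inhibitor), compound 1 gives 610 nM, while compound 2 gives 2530 nM, the higher of the two numbers, the step being a 4.1-fold higher number from compound 1 to compound 2 (0.62 log units; beyond the scatter). Compound 3 `CC(=O)OC[C@@H](OCc1ccccc1)[C@H]1OC(=O)C=C[C@H]1OCc1ccccc1` departs from compound 2 by a broader change: methyl in place of 2-(4-nitrophenyl)ethenyl on a carbonyl carbon. Within the data shown here, no measured step covers this exchange; the only known step, a 4.1-fold higher number from compound 1 to compound 2 (0.62 log units; beyond the scatter), concerns the nitro alone. Since the nitro leaves with the rest, the number is expected to move back toward that of compound 1, 610 nM. Compound 3 is therefore expected near 1000 nM, with a range from 300 nM to 4000 nM. That would be an expected step of a 2.5-fold lower number from compound 2 to compound 3 (0.40 log units; beyond the scatter).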

Compound 3, half-maximal inhibitory concentration: 9230 nM
Beside the measured number, compound 3's estimate is 9.2-fold (0.97 log units) below it; the measured number lies above the stated range.
By their numbers in this assay, from the lowest: compound 1; then compound 2; then compound 3.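

In this assay, methyl in place of 2-(4-nitrophenyl)ethenyl on the carbonyl carbon gives a 3.6-fold higher number from compound 2 to compound 3 (0.56 log units; beyond the scatter), and methyl in place of 2-phenylethenyl gives a 15-fold higher number from compound 1 to compound 3 (1.18 log units; beyond the scatter). The position therefore tolerates the nitro-bearing chain better than the bare methyl, even though the nitro itself weakens the number, and the larger chains on this carbonyl carbon matter for activity. Nothing available explains this loss. The compounds leave open whether the aromatic ring or the double bond counts, which a saturated 2-phenylethyl chain would separate. From the compounds shown here alone, how an amine on the ring would read also remains open.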